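The source may hold more compounds than are shown below. What is called first, only, known or untested is meant among the compounds shown, and "the series" means these compounds.

Measured so far:
Compound 1, `C=C1CC[C@H]2C(C)(C)CCC[C@]2(C)[C@H]1CC/C(C)=C/Cc1c(O)cc2oc(-c3ccc(O)cc3)c(O)c(=O)c2c1O`: in a functional assay on HeLa cells (Homo sapiens) for cytotoxicity, read by XTT assay, with a stated time of 72 h (on this read-out lower numbers stand for stronger inhibition and higher numbers for weaker inhibition), compound 1 gives > 100000 nM, which is a limit of the assay rather than a number.
Compound 2, `CC(C)=CCC/C=C(\C)Cc1c(O)cc(O)c2c(=O)c(OC/C=C(\C)CCC=C(C)C)c(-c3ccc(O)cc3)oc12`: in this assay compound 2 gives 27000 nM.

Within the data shown here, compound 2 therefore stands as the only compound with a real number in this assay; the other result sits at the limit of > 100000 nM in this assay, at which 1 of the 2 values shown sits, so no measured comparison between two numbers exists here. Compound 2 carries two unsaturated chains on its core, one of them a 3,7-dimethylocta-2,6-dien-1-yl group attached through an oxygen on an aromatic ring.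

Compound 3, `CC(C)=CCC/C=C(\C)Cc1c(O)cc(O)c2c(=O)c(O)c(-c3ccc(O)cc3)oc12`, keeps the core of compound 2 but differs in one place: hydrogen in place of 3,7-dimethylocta-2,6-dien-1-yl on an oxygen on an aromatic ring. Among the measured compounds shown here, no measured pair shows what such a change does in this assay, so the expectation rests on compound 2 alone. Removing a chain of this size is expected to shift the read-out by a modest amount, most likely toward weaker inhibition, though a result within the scatter of compound 2 would not be surprising. Compound 3 is expected to give about 45000 nM, within a range of 15000 nM to 100000 nM, corresponding to an estimated step of a 1.7-fold higher number from compound 2 to compound 3 (0.22 log units; within the scatter).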

Compound 3, half-maximal inhibitory concentration: 30000 nM
The estimate for compound 3 lay 1.5-fold (0.18 log units) above the measured number, within the range that was stated.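

Among these compounds, the pair gives the first measured comparison between two numbers in this assay, and it concerns the oxygen on an aromatic ring that carries the 3,7-dimethylocta-2,6-dien-1-yl chain in compound 2 and only a hydrogen in compound 3. Exchanging (3,7-dimethylocta-2,6-dien-1-yl)oxy for hydroxy gives a 1.1-fold higher number from compound 2 to compound 3 (0.05 log units; within the scatter), so the 3,7-dimethylocta-2,6-dien-1-yl chain can leave this oxygen with no difference that can be told from the usual spread of repeated measurements, and the two compounds read as equal in this pair. The one line of data on hand, a limit for a different compound, offers no reason for this result.

Still open, from the compounds shown here alone, is whether a group of another kind on this same oxygen, such as a small methyl or a short chain ending in an amine or a carboxylic acid, would read any differently from hydroxy or the long chain. Also open is what part the second 3,7-dimethylocta-2,6-dien-1-yl chain, shared by compound 2 and compound 3, plays in the read-out, as no compound shown lacks it while keeping the rest of the structure unchanged.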